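Replacing the Bromophenyl with a Pyridine Ring

The source may hold more compounds than are shown below. What is called first, only, known or untested is meant among the compounds shown, and "the series" means these compounds.

Compound 1 `COc1ccc(C(=O)/C=C/c2ccc(Br)cc2)c2c1C=CC(C)(C)O2` is the starting point of this comparison. In a functional assay on SK-OV-3 cells (Homo sapiens) for antiproliferative activity, read by MTT assay, with a stated time of 24 h (a lower number here means a stronger inhibitor, a higher number a weaker inhibitor), compound 1 gives > 10000 nM, which is a limit of the assay and not a number. Two measured neighbours of compound 1 differ from it only at the aromatic carbon that carries the bromo group. Compound 2 `COc1ccc(C(=O)/C=C/c2ccc(-n3ccnc3)cc2)c2c1C=CC(C)(C)O2` has 1H-imidazol-1-yl at that carbon and gives 7200 nM in this assay. Compound 3 `COc1ccc(C(=O)/C=C/c2ccc(C(F)(F)F)cc2)c2c1C=CC(C)(C)O2` has trifluoromethyl at that carbon, and compound 3 gives > 10000 nM, again a limit of the assay. The step is an at least 1.3-fold lower number from compound 1 to compound 2 (0.14 log units; that floor lies within the scatter), the step that the two limits leave unreadable from compound 1 to compound 3, and the step of an at least 1.3-fold higher number from compound 2 to compound 3 (0.14 log units; that floor lies within the scatter). the limit of > 10000 nM in this assay, at which 2 of the 3 values shown sit, is where two of the three values sit, so little of the measured landscape can be read as a trend.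

Compound 4 `COc1ccc(C(=O)/C=C/c2ccccn2)c2c1C=CC(C)(C)O2` has not yet been measured. It changes more than either neighbour: pyridin-2-yl in place of 4-bromophenyl on a double-bonded chain carbon bound to a double-bonded chain carbon. Going by the values given here, the only readable step, that from compound 1 to compound 2, did not clearly move beyond the scatter, and compound 3 stayed at the limit. Compound 4 is therefore expected to give about 9000 nM in this assay, within 3000 nM to 30000 nM. That estimate means the step of an at least 1.1-fold lower number from compound 1 to compound 4 (0.04 log units; that floor lies within the scatter), and it is expected to carry no direction beyond the scatter.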

Compound 4, half-maximal inhibitory concentration: 8390 nM
Compound 4: the middle estimate sits 1.1-fold (0.03 log units) above what was measured, within the range that was stated.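

Setting pyridin-2-yl in place of 4-bromophenyl on a double-bonded chain carbon bound to a double-bonded chain carbon gives an at least 1.1-fold lower number from compound 1 to compound 4 (0.07 log units; that floor lies within the scatter) in this assay, so this exchange shows no step beyond the scatter. The earlier neighbours changed only the group on an aromatic carbon and kept the six-membered ring of carbon, whereas compound 4 exchanges that ring itself for one with a hetero atom and still gives a measured number, not a limit. Going by these compounds alone, the value of compound 1, > 10000 nM, is a limit of the assay and not a number, and the one step between the two limits cannot be read, so the series offers little as a trend: the limit of > 10000 nM in this assay, at which 2 of the 4 values shown sit.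

The compounds shown leave open whether a pyridin-3-yl or pyridin-4-yl group would read any differently from pyridin-2-yl in this assay. They also leave open whether an amine or a carboxylic acid on the pyridine ring, or a longer chain in place of that ring, would produce a step beyond the scatter.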